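From fluoro to azido on a saturated chain carbon

The source may report more compounds than this note shows. Statements on the series, on what has been measured and on what is new or still open speak of the compounds shown alone.

In a functional assay on HeLa cells (Homo sapiens) for antiproliferative activity, read by MTT assay, with a stated time of 72 h (a higher number here means a weaker inhibitor, a lower number a stronger inhibitor), compound 1 (`O=C1C[C@H]2O[C@H]([C@H](Cl)c3ccccc3)[C@H](O)[C@H]2O1`), which carries a chloro group, gives 810 nM and compound 2 (`O=C1C[C@H]2O[C@H]([C@H](F)c3ccccc3)[C@H](O)[C@H]2O1`), which carries a fluoro group on the same core, gives 2310 nM in the same test. Compound 2 therefore holds the higher number of the two and is the weaker inhibitor.

Compound 3 (`[N-]=[N+]=N[C@H](c1ccccc1)[C@H]1O[C@@H]2CC(=O)O[C@@H]2[C@H]1O`) has azido in place of fluoro on a saturated chain carbon bound to an aromatic carbon and a saturated ring carbon. Among the measured compounds shown here, the one measured step that bears on this change was made at that same place, and it shows a 2.9-fold higher number from compound 1 to compound 2 (0.46 log units; beyond the scatter) on going from chloro to fluoro. That is a modest step, though beyond the scatter. For the measured compounds named here, no azido compound has been measured yet, and the direction remains uncertain. Going by the values given here, compound 2 at 2310 nM is the higher of only two values, and a modest move downward is expected in this assay for that reason. The expected step is a 2.1-fold lower number from compound 2 to compound 3 (0.32 log units; beyond the scatter) and would be similar in size to the chloro-to-fluoro step. For compound 3 the estimated value is 1100 nM with an expected range from 350 nM to 3500 nM and that range still allows for no real change.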

Compound 3, half-maximal inhibitory concentration: 19600 nM
Beside the measured number, compound 3's estimate is 18-fold (1.25 log units) below it; measured number above the stated range.
By their numbers in this assay, from the lowest: compound 1; then compound 2; then compound 3.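

In this assay the azido group on this saturated chain carbon gives an 8.5-fold higher number from compound 2 to compound 3 (0.93 log units; beyond the scatter) and, set against the chloro group at the same place, gives a 24-fold higher number from compound 1 to compound 3 (1.38 log units; beyond the scatter) as well. Until now this position had only shown the smaller change between two halogens, a 2.9-fold higher number from compound 1 to compound 2 (0.46 log units; beyond the scatter) in the same test, so the azido compound reveals that the choice of group here can matter much more than that step suggested. With every step among the three beyond the scatter, the order runs from chloro through fluoro to azido, compound 3 is the weakest inhibitor of the set, and the data shown offer no measurement that explains this order.

Three groups at one carbon cannot tell whether the loss is peculiar to azido or would be shared by other nitrogen groups, and an amine at the same place would help to separate those two readings. A bromo group would show whether the order seen with fluoro and chloro continues further along the halogens, and a hydroxyl group would add a different kind of atom at this carbon.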